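The compounds below may be only part of what the source reports. "The series", "measured", "known", "first", "only" and "open" are said of these compounds alone.

Four close relatives of one furan-bearing ether are compared here in an ADME assay on J774.A1 cells (Mus musculus) for cytotoxicity, read by MTT assay, with a stated time of 72 h; a higher number here means that more compound is tolerated, a lower number that less compound is tolerated. Compound 1, `Clc1ccc(Cl)c(COC(CCn2ccnc2)c2ccco2)c1`, carries a dichlorinated benzyl ether and gives 37600 nM in this assay. Compound 2, `Clc1ccc(Cl)c(COC(CCn2cncn2)c2ccco2)c1`, keeps the same dichlorinated core and gives 28900 nM in this assay. The two differ only in one five-membered ring: 1H-imidazol-1-yl in place of 1H-1,2,4-triazol-1-yl on a saturated chain carbon, three bonds along the chain from an aromatic carbon and an oxygen on a saturated carbon. That change gives a 1.3-fold higher number from compound 2 to compound 1 (0.11 log units; within the scatter), so the two compounds are tolerated to about the same degree.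

Compound 3, `Fc1ccc(F)c(COC(CCn2cncn2)c2ccco2)c1`, has fluorine in place of both chlorines; for compound 3 the result in this assay reads "not determined" (no result reported), so no number is available for it. Compound 4, `Fc1ccc(F)c(COC(CCn2ccnc2)c2ccco2)c1`, is built from compound 3 by the same ring swap seen between compound 2 and compound 1: 1H-imidazol-1-yl in place of 1H-1,2,4-triazol-1-yl on a saturated chain carbon, three bonds along the chain from an aromatic carbon and an oxygen on a saturated carbon. The difference between the core of compound 3 and the core of compound 2 is not broken down here.

For the measured compounds named here, since the place of the swap is the same in both pairs, the change from compound 3 to compound 4 is expected to be of a size like the one from compound 2 to compound 1, which lay within the scatter. With no number for compound 3, the expectation for compound 4 has to lean on the dichlorinated pair, with added uncertainty for the different core. Compound 4 is therefore expected to give about 40000 nM in this assay, estimated between 15000 nM and 110000 nM.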

Compound 4, half-maximal cytotoxic concentration: 30900 nM
Beside the measured number, compound 4's estimate is 1.3-fold (0.11 log units) above it, and the stated range covers the measured number.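

Compound 3 has no number in this assay, so the ring swap that leads from compound 3 to compound 4 cannot be read as a step. The compounds shown leave open whether this swap changes the tolerated concentration on the core of compound 4 as little as it does between compound 2 and compound 1. No measured finding here explains the value of compound 4.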